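A few compounds are considered here, and "the series" means these few. Any claim that something is new, unique, unknown or untested is made for them only; others in the source may bear on it.

Compound 1 `Cc1c(O)nc(S(=O)(=O)Cc2ccc([N+](=O)[O-])cc2)nc1Cc1c(Cl)cccc1Cl` and compound 2 `COc1ccc(CSc2nc(O)c(C)c(Cc3ccc(F)cc3)n2)cc1` share their core with compound 3 `CCOc1ccc(CSc2nc(O)c(C)c(Cc3c(Cl)cccc3Cl)n2)cc1`. In a functional assay on MT4 cells (Homo sapiens) for cytotoxicity, read by MTT assay (a higher number here means that more compound is tolerated, a lower number that less compound is tolerated), compound 3 reaches only a limit of the assay, > 58000 nM, which is what the limit of > 58000 nM in this assay, at which 1 of the 3 values shown sits, records. Compound 1 likewise gives a limit, > 53000 nM, recorded by the limit of > 53000 nM in this assay, at which 1 of the 3 values shown sits. Compound 2 gives a number instead, 8900 nM in this assay. Compound 3 therefore stands with the tolerated compounds, at a limit rather than a number. Compound 4 `CCCCOc1ccc(CSc2nc(O)c(C)c(Cc3c(Cl)cccc3Cl)n2)cc1` differs from compound 3 by ethyl in place of hydrogen on a saturated chain carbon, two bonds along the chain from an oxygen on an aromatic ring. Going by the values given here, no measured pair carries this same change, so the step in this assay is expected to be small, none beyond the scatter, and a limit again is likely. Compound 4 is expected to give 50000 nM, between 15000 nM and 100000 nM. The expected step is an at least 1.1-fold lower number from compound 3 to compound 4 (0.06 log units; that floor lies within the scatter).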

Compound 4, half-maximal cytotoxic concentration: 3100 nM
For compound 4 the middle estimate is 16-fold (1.21 log units) above the measured one; measured number outside the range, below it.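

In this assay the change from ethoxy to butoxy gives an at least 18-fold lower number from compound 3 to compound 4 (1.27 log units; beyond the scatter) and so less compound is tolerated. The outer end of the chain on this oxygen therefore matters for tolerance on these cells, even with the rest of the molecule unchanged. The step is only a floor, as compound 3 sits at a limit of the assay: the limit of > 58000 nM in this assay, at which 1 of the 4 values shown sits.

The compounds shown do not say why this step arises. They also leave open whether a propoxy group, a hexyloxy group or an amine at the chain end would be tolerated.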